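Propargyl for allyl on the oxime ether side

A few compounds are considered here, and "the series" means these few. Any claim that something is new, unique, unknown or untested is made for them only; others in the source may bear on it.

The measured compounds:
compound 1, `C=CCOc1c(Cl)cc(N/C=N/OCC)cc1Cl`, 4.3
compound 2, `C#CCOc1c(Cl)cc(N/C=N/OCC)cc1Cl`, 3.6
compound 3, `C#CCc1c(Cl)cc(N/C=N/OCC=C)cc1Cl`, 3.7

In a physicochemical assay for lipophilicity, measured as octanol-water partition (a lower number here means a more polar compound, a higher number a more lipophilic compound), compound 1 gives 4.3. Compound 2 differs by ethynyl in place of vinyl on a saturated chain carbon bound to an oxygen on an aromatic ring, and in this assay compound 2 gives 3.6; the step of a number 0.70 log units lower from compound 1 to compound 2 (beyond the scatter). How the core of compound 3 differs from that of compound 1 is not broken down here. In this assay compound 3 gives 3.7, which lies within the scatter of compound 2 and beyond it relative to compound 1.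

Compound 4, `C#CCO/N=C/Nc1cc(Cl)c(CC#C)c(Cl)c1`, is not yet measured. It differs from compound 3 by ethynyl in place of vinyl on a saturated chain carbon bound to an oxygen. This is the same kind of change as that from compound 1 to compound 2, but there the saturated chain carbon was bound to an oxygen on an aromatic ring, whereas here the oxygen is not on an aromatic ring. For the measured compounds named here, for compound 4 a step of a number 0.60 log units lower from compound 3 to compound 4 (beyond the scatter) in this assay is expected, resting on the single earlier step of a number 0.70 log units lower from compound 1 to compound 2 (beyond the scatter), with added uncertainty because the surroundings of the change differ. The estimate for compound 4 in this assay is 3.1, between 2.6 and 3.6.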

Compound 4, partition coefficient: 3.3
Beside the measured number, compound 4's estimate is 0.20 log units below it; the measured number falls inside the stated range.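

In this assay the change from vinyl to ethynyl on a saturated chain carbon bound to an oxygen again goes with a number 0.40 log units lower from compound 3 to compound 4 (beyond the scatter) and so runs the same way as the earlier change on the core of compound 1, where the oxygen was on an aromatic ring and the result was a number 0.70 log units lower from compound 1 to compound 2 (beyond the scatter) in the same read-out. Both steps lie beyond the scatter, so the direction of the change carried over between these two cores even though its surroundings differ. Two pairs do not fix a size for the change or show that it would hold on any further core, and nothing given here bears on why the number falls.

The compounds shown carry only vinyl and ethynyl at this place, so they leave open how a longer chain, an amine or a carboxylic acid would read there in this assay. They also leave open whether the direction of the step would persist on a third core.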